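This account rests on a few compounds, and the source may have more. Where it says the series, first, only, none or still open, it means among the compounds named here.

Measured so far in a functional assay on HEK293 cells for agonist activity at Free fatty acid receptor 1 (Homo sapiens), read by fluorescence and calcium flux, with a stated time of 10 min; a higher number here means that more compound is needed for the effect, a lower number that less compound is needed:
compound 1 `O=C(O)CCc1ccc(OCC2COc3ccc(Cl)cc3O2)cc1F`: 830 nM
compound 2 `O=C(O)CC1(c2ccc(OCC3COc4ccc(Cl)cc4O3)cc2)COC1`: 8060 nM
compound 3 `CC#C[C@@H](CC(=O)O)c1ccc(OC[C@H]2COc3ccc(F)cc3O2)cc1`: 210 nM

Compound 3 gives the lowest of the three numbers in this assay. Compound 1 sits above it by a margin beyond the usual scatter, and compound 2 lies further above, also beyond the scatter. Compound 4 `CC#C[C@@H](CC(=O)O)c1ccc(OC[C@H]2COc3ccc(S(C)(=O)=O)cc3O2)cc1` follows from compound 3 by a single change, (methylsulfonyl in place of fluoro on an aromatic carbon). Within the data shown here, no pair of measured compounds shows this exchange, so the size of the step has no precedent. Some shift in this assay is expected, most likely a modest rise in the number rather than a fall, though one that may not exceed the scatter. For compound 4 the estimate is 320 nM, with a range from 80 nM to 1300 nM, which corresponds to an expected step of a 1.5-fold higher number from compound 3 to compound 4 (0.18 log units; within the scatter).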

Compound 4, half-maximal effective concentration: 27200 nM
Beside the measured number, compound 4's estimate is 85-fold (1.93 log units) below it, outside the stated range (above it).
By their numbers in this assay, from the lowest: compound 3; then compound 1; then compound 2; then compound 4.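

In this assay, among these compounds, methylsulfonyl in place of fluoro on this aromatic carbon gives a 130-fold higher number from compound 3 to compound 4 (2.11 log units; beyond the scatter), the first step that can be read as a single exchange. This position is therefore far from indifferent to what it carries, and a sulfone here costs much of the activity of compound 3. No measurement shown accounts for the size of this step.

On these data alone, whether the large rise belongs to methylsulfonyl alone remains open. A nitrile or a methoxy group on the same aromatic carbon would show how far it extends to other groups.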